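Chromone ethers at the sigma-1 site: amine head replaced

This account rests on a few compounds, and the source may have more. Where it says the series, first, only, none or still open, it means among the compounds named here.

Compound 1 `CN(CCCCCCOc1ccc2oc(-c3ccccc3)cc(=O)c2c1)Cc1ccccc1` gives 75 nM in an assay on isolated protein (Cavia porcellus) with Sigma non-opioid intracellular receptor 1 (Homo sapiens) as the target, read by radioligand binding; on this read-out lower numbers stand for stronger inhibition and higher numbers for weaker inhibition. Compound 2 `O=c1cc(-c2ccccc2)oc2ccc(OCCCCCCN3CCNCC3c3ncccn3)cc12` gives 14200 nM.

Within the data shown here, compound 2 carries the highest number of the two measured compounds; the gap to compound 1 is the single measured step, a 190-fold higher number from compound 1 to compound 2 (2.28 log units; beyond the scatter), well beyond the scatter. Compound 3 `CCOC(=O)C1CCN(CCCCCCOc2ccc3oc(-c4ccccc4)cc(=O)c3c2)CC1` differs from compound 2 by 4-(ethoxycarbonyl)piperidin-1-yl in place of 2-(pyrimidin-2-yl)piperazin-1-yl on a saturated chain carbon, six bonds along the chain from an oxygen on an aromatic ring. Among the measured compounds shown here, no measured pair shows this exact exchange, so the expectation rests on the one step at hand: the move to the 2-(pyrimidin-2-yl)piperazin-1-yl head cost a great deal, and compound 3 removes that head in favour of a single-nitrogen saturated ring bearing an ester. Since compound 1 and compound 3 share the shared core, the chain and a tertiary amine without the pyrimidine, compound 3 is expected to recover part of that loss, so a large step toward lower numbers, a 24-fold lower number from compound 2 to compound 3 (1.37 log units; beyond the scatter), is estimated, without reaching compound 1. Compound 3 is therefore expected to give about 600 nM in this assay, within 120 nM to 3000 nM.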

Compound 3, half-maximal inhibitory concentration: 102 nM
Compound 3: the middle estimate sits 5.9-fold (0.77 log units) above what was measured, outside the stated range (below it).
By their numbers in this assay, from the lowest: compounds 1 and 3 (each within the scatter of the next); then compound 2.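

In this assay, putting 4-(ethoxycarbonyl)piperidin-1-yl in place of 2-(pyrimidin-2-yl)piperazin-1-yl on a saturated chain carbon, six bonds along the chain from an oxygen on an aromatic ring, gives a 140-fold lower number from compound 2 to compound 3 (2.14 log units; beyond the scatter) and so shows that the high number of compound 2 is not shared by every saturated ring head at this place. Set against benzyl(methyl)amino, the same head gives a 1.4-fold higher number from compound 1 to compound 3 (0.13 log units; within the scatter) and this lies within the scatter, so compound 1 and compound 3 cannot be told apart here although their amine heads differ. No supporting measurement is available to explain the large step or the match between these two compounds.

The compounds shown do not separate the pyrimidin-2-yl group from the second ring nitrogen of the piperazine as the source of the high number of compound 2, a question that a plain piperazin-1-yl head would address. On these data alone, whether the ethoxycarbonyl group contributes to the value of compound 3 also stays open, and an unsubstituted piperidin-1-yl head or a 4-carboxypiperidin-1-yl head would bear on that.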